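A Methyl Group Added to Compound 2

This account rests on a few compounds, and the source may have more. Where it says the series, first, only, none or still open, it means among the compounds named here.

In a functional assay on NCI-H460 cells (Homo sapiens) (a lower number here means a stronger inhibitor of growth, a higher number a weaker inhibitor of growth), compound 2 `COc1ccccc1-c1cc(O)c2cccnc2n1` gives 38900 nM, the second highest of three numbers. Compound 1 `COc1ccccc1-c1cc(O)c2ccc(C)nc2n1` stands higher at 97700 nM. Compound 3 `COc1cccc(-c2cc(O)c3c(C)ccnc3n2)c1` differs from the others in more than one place and stands far lower at 47.9 nM.

Compound 4 `COc1ccccc1-c1cc(O)c2cc(C)cnc2n1` carries one change from compound 2: methyl in place of hydrogen on an aromatic carbon, two atoms from the ring nitrogen. Among the compounds with values here, the only measured single-place step involves a methyl on a different carbon: a 2.5-fold lower number from compound 1 to compound 2 (0.40 log units; beyond the scatter), a modest step on losing that methyl. Adding a methyl here may therefore raise the number in this assay slightly, perhaps no further than the scatter.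

For compound 4 the estimated value is 60000 nM, within a range of 20000 nM to 150000 nM. The expected change is a 1.5-fold higher number from compound 2 to compound 4 (0.19 log units; within the scatter).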

Compound 4, concentration for 50% growth inhibition: 32400 nM
Beside the measured number, compound 4's estimate is 1.9-fold (0.27 log units) above it; measured number inside the range.
By their numbers in this assay, from the lowest: compound 3; then compounds 4 and 2 (each within the scatter of the next); then compound 1.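

In this assay, a methyl group on this carbon, two atoms from the ring nitrogen, gives a step within the scatter: a 1.2-fold lower number from compound 2 to compound 4 (0.08 log units; within the scatter). The methyl on a different carbon gave a step beyond the scatter, a 2.5-fold lower number from compound 1 to compound 2 (0.40 log units; beyond the scatter), so a methyl does not shift the number by a clear margin at every carbon of this ring. No measurement on hand offers an explanation for this result.

Going by these compounds, whether an amine or a longer chain on this carbon would also stay within the scatter remains open. Compound 3, at 47.9 nM, differs in more than one place, so its value cannot be traced to any single change.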